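The source may hold more compounds than are shown below. What is called first, only, known or untested is meant among the compounds shown, and "the series" means these compounds.

Of the compounds shown here, three built on the same sulfonamide core have been measured in a functional assay on BE(2)-C cells (Homo sapiens) for inhibition, read by MTT assay, with a stated time of 72 h; on this read-out higher numbers stand for weaker inhibition of growth and lower numbers for stronger inhibition of growth. Compound 1 `CN(CCCNS(=O)(=O)c1cc(C(F)(F)F)cc(C(F)(F)F)c1)Cc1ccccc1` gives 28000 nM in this assay. Compound 2 `O=S(=O)(NCCCNCc1cccc2ccccc12)c1cc(C(F)(F)F)cc(C(F)(F)F)c1` gives 2700 nM. Compound 3 `COc1ccc(CNCCCNS(=O)(=O)c2cc(C(F)(F)F)cc(C(F)(F)F)c2)cc1` gives 2800 nM, which places it second highest of the three numbers, within the scatter of compound 2 and far from compound 1.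

Two measured steps lead into compound 3. One is a 10-fold lower number from compound 1 to compound 3 (1.00 log units; beyond the scatter), a modest gain that comes with reworking the amine end of the chain. The other is a 1.0-fold higher number from compound 2 to compound 3 (0.02 log units; within the scatter), showing that exchanging one aromatic group for a rather different one on the carbon next to the amine nitrogen made no difference beyond the scatter.

Compound 4 `COc1cccc(CNCCCNS(=O)(=O)c2cc(C(F)(F)F)cc(C(F)(F)F)c2)c1` differs from compound 3 in a single respect: 3-methoxyphenyl in place of 4-methoxyphenyl on a saturated chain carbon bound to an amine nitrogen. The same atoms are present; only the methoxy group has moved around the ring. Of the two steps, only the second bears on this, since it also varies the aromatic group in this position, and it was flat. A change of this kind is therefore expected to give a 1.1-fold higher number from compound 3 to compound 4 (0.03 log units; within the scatter), nothing beyond the scatter. The estimate for compound 4 in this assay is 3000 nM, with a likely range from 1000 nM to 9000 nM.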

Compound 4, concentration for 50% growth inhibition: 4500 nM
The estimate for compound 4 lay 1.5-fold (0.18 log units) below the measured number, and the stated range covers the measured number.
By their numbers in this assay, from the lowest: compounds 2, 3 and 4 (each within the scatter of the next); then compound 1.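

Moving the methoxy group, with 3-methoxyphenyl in place of 4-methoxyphenyl on a saturated chain carbon bound to an amine nitrogen, gives a 1.6-fold higher number from compound 3 to compound 4 (0.21 log units; within the scatter) in this assay, so in this pair the place of the methoxy group on the ring makes no difference beyond the scatter. The 3-methoxyphenyl group also matches naphthalen-1-yl, with a 1.7-fold higher number from compound 2 to compound 4 (0.22 log units; within the scatter), so all three aromatic groups on this carbon now read alike, while a 6.2-fold lower number from compound 1 to compound 4 (0.79 log units; beyond the scatter) shows that the gap to compound 1 remains with the new group in place. Nothing measured here speaks to what lies behind these numbers.

Still open, as far as these compounds go, is whether a plain benzylamino group would read like compound 3 and compound 4 or like compound 1, a result that would help separate the effect of the methyl on the amine nitrogen from that of the ring groups. Also open, from the compounds shown here alone, is how a different ring group, such as a hydroxyl or a fluorine in place of the methoxy group, would read.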